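A Benzylsulfonyl Variant in a Series of Limits

A few compounds are considered here, and "the series" means these few. Any claim that something is new, unique, unknown or untested is made for them only; others in the source may bear on it.

Three compounds share one core and differ only in the group on the ring nitrogen. Compound 1 `COc1ccc(-c2cc(=O)c3c(OC)cc(OC)cc3n2Cc2ccccc2)cc1` carries a benzyl group there, compound 2 `COc1ccc(-c2cc(=O)c3c(OC)cc(OC)cc3n2S(=O)(=O)c2ccc([N+](=O)[O-])cc2)cc1` a 4-nitrophenylsulfonyl group, and compound 3 `COc1ccc(-c2cc(=O)c3c(OC)cc(OC)cc3n2S(=O)(=O)c2c(F)c(F)c(F)c(F)c2F)cc1` a 2,3,4,5,6-pentafluorophenylsulfonyl group. In a functional assay on HepG2 cells (Homo sapiens) for antiproliferative activity, with a stated time of 72 h (on this read-out higher numbers stand for an effect only at larger amounts of compound and lower numbers for an effect already at smaller amounts), compound 1 gives > 17300 nM, which is a limit of the assay rather than a number. Compound 2 likewise reaches only the limit > 29300 nM. Compound 3 stands at the limit > 34400 nM in this assay. With all three values sitting at limits (the limit of > 17300 nM in this assay, at which 1 of the 3 values shown sits, (the limit of > 29300 nM in this assay, at which 1 of the 3 values shown sits), (the limit of > 34400 nM in this assay, at which 1 of the 3 values shown sits)), compound 3 cannot be ranked against the others, and the step from compound 2 to compound 3 remains a step that the two limits leave unreadable from compound 2 to compound 3.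

Compound 4 `COc1ccc(-c2cc(=O)c3c(OC)cc(OC)cc3n2S(=O)(=O)Cc2ccccc2)cc1` is the next variant: benzyl in place of 2,3,4,5,6-pentafluorophenyl on a sulfonyl sulfur. For the measured compounds named here, the only measured step at the same position is a step that the two limits leave unreadable from compound 2 to compound 3, which offers no readable size, so no direction beyond the scatter can be expected for the step from compound 3 to compound 4. Compound 4 is therefore also expected to sit at a limit, the estimated step being an at least 1.1-fold lower number from compound 3 to compound 4 (0.05 log units; that floor lies within the scatter). For compound 4 the estimate in this assay is 30000 nM, ranging from 8000 nM to 100000 nM.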

Compound 4, half-maximal effective concentration: > 34400 nM
Compound 4 was reported as a limit; the forecaster's own chance of this, stated with the estimate: 85%; at least 1.1-fold (0.05 log units) between middle value and limit.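

In this assay compound 4 reaches only > 34400 nM, which is a limit of the assay and not a number. Its steps from compound 1, compound 2 and compound 3 therefore cannot be read: the limit of > 34400 nM in this assay, at which 2 of the 4 values shown sit.

The compounds shown leave open whether the four groups on the aromatic nitrogen differ at all in this assay.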